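The compounds below may be only part of what the source reports. "The series", "measured", "known", "first", "only" and "open" are said of these compounds alone.

Measured compounds:
compound 1 `CN(C)CCNc1nc(-c2ccc(NC(=O)Nc3ccc(Cl)cc3)cc2)nc2c(Cl)c(Cl)sc12` — 870 nM
compound 2 `CN(C)CCNc1nc(-c2ccc(NC(=O)Nc3ccc(Cl)cc3Cl)cc2)nc2c(Cl)c(Cl)sc12` — 3500 nM

In a functional assay on MDA-MB-231 cells (Homo sapiens) for cytotoxicity, read by MTT assay, with a stated time of 72 h (on this read-out lower numbers stand for stronger inhibition and higher numbers for weaker inhibition), compound 1 gives 870 nM and compound 2 gives 3500 nM; compound 2 therefore holds the higher of the two numbers, and the step of a 4.0-fold higher number from compound 1 to compound 2 (0.60 log units; beyond the scatter) lies beyond the scatter. Compound 3 `CCN(CC)CCCNc1nc(-c2ccc(NC(=O)Nc3ccc(Cl)cc3Cl)cc2)nc2c(Cl)c(Cl)sc12` differs from compound 2 by (diethylamino)methyl in place of dimethylamino on a saturated chain carbon, two bonds along the chain from a nitrogen on an aromatic ring. For the measured compounds named here, no measured step touches this part of the molecule: the only measured step, a 4.0-fold higher number from compound 1 to compound 2 (0.60 log units; beyond the scatter), concerns a chloro on an aromatic carbon elsewhere. With nothing to point a direction, no step beyond the scatter is expected in this assay. Compound 3 is thus expected at 3500 nM (range 1200 nM to 10000 nM), a step of no change at the digits printed from compound 2 to compound 3 (within the scatter).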

Compound 3, half-maximal inhibitory concentration: 3940 nM
The estimate for compound 3 lay 1.1-fold (0.05 log units) below the measured number; the measured number falls inside the stated range.
By their numbers in this assay, from the lowest: compound 1; then compounds 2 and 3 (each within the scatter of the next).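

In this assay, replacing dimethylamino with (diethylamino)methyl on the saturated chain gives a 1.1-fold higher number from compound 2 to compound 3 (0.05 log units; within the scatter). This first change at this position shows that going from 3 to 6 heavy atoms in this group does not shift the number beyond the scatter, at least with the rest of the molecule as in compound 2. No evidence is available here to explain this result.

On these data alone, the change alters the chain length and the groups on the nitrogen together, so their separate contributions remain unknown. Also open, as far as these compounds go, is how a morpholine or a hydroxyl group at the chain end would behave.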